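Carbonate prodrug esters: isopropyl to tert-butyl on the shared core

The source may report more compounds than this note shows. Statements on the series, on what has been measured and on what is new or still open speak of the compounds shown alone.

Measured so far in a physicochemical assay for metabolic stability, read by LC-MS, in phosphate buffer, with a stated time of 3 h, at pH 7.4, tested at 50 uM; on this read-out lower numbers stand for a less stable compound and higher numbers for a more stable compound:
Compound 1 `CC(C)OC(=O)OCOC(=O)C1=C(S[C@@H]2CN[C@H](C(=O)Nc3cccc(C(=O)O)c3)C2)[C@H](C)[C@@H]2[C@@H]([C@@H](C)O)C(=O)N12` gives > 95%, a limit of the assay.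
Compound 2 `CC(C)OC(=O)OCOC(=O)C1=C(S[C@@H]2CN[C@H](C(=O)Nc3cccc(C(=O)OCOC(=O)OC(C)C)c3)C2)[C@H](C)[C@@H]2[C@@H]([C@@H](C)O)C(=O)N12` gives > 95%, likewise a limit.
Compound 3 `COC(=O)OCOC(=O)C1=C(S[C@@H]2CN[C@H](C(=O)Nc3cccc(C(=O)OCOC(=O)OC)c3)C2)[C@H](C)[C@@H]2[C@@H]([C@@H](C)O)C(=O)N12` gives > 95%, also a limit.

Compound 1 therefore stands only at a limit, as do the two other compounds; (the limit of > 95% in this assay, at which 3 of the 3 values shown sit). For the measured compounds named here, the one single-point step, a step that the two limits leave unreadable from compound 1 to compound 2, cannot be sized from two limits.

Compound 4 `C[C@@H](O)[C@H]1C(=O)N2C(C(=O)OCOC(=O)OC(C)(C)C)=C(S[C@@H]3CN[C@H](C(=O)Nc4cccc(C(=O)O)c4)C3)[C@H](C)[C@H]12` differs from compound 1 by methyl in place of hydrogen on a saturated chain carbon bound to an oxygen next to a carbonyl group and two saturated chain carbons. No measured step bears on this change, and none of the shown steps has a readable size. The expectation for compound 4 in this assay is therefore a step that the limit leaves unreadable from compound 1 to compound 4 from compound 1, no change beyond the scatter. Compound 4 is estimated at 96%, within 90% to 100%.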

Compound 4, percent of the compound remaining: > 95%
Compound 4: a limit, no number (the forecaster's own chance of this, stated with the estimate: 85%); the middle value lies beyond the limit too.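

Compound 1 and compound 4 both sit at a limit in this assay, so no new step can be read from this pair: the limit of > 95% in this assay, at which 4 of the 4 values shown sit.
The compounds shown leave open whether isopropyl to tert-butyl shifts this read-out at all, and by how much.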